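This account rests on a few compounds, and the source may have more. Where it says the series, first, only, none or still open, it means among the compounds named here.

Compound 1, `Cc1ccnc(OC(c2ccc(C(F)(F)F)cc2)C2CCN(C(C)CCNC(=O)c3c(Cl)cncc3Cl)CC2)c1`, is the starting point. In an ADME assay on PBMC cells (Homo sapiens) for cytotoxicity (on this read-out higher numbers stand for lower toxicity in this test and lower numbers for higher toxicity in this test), compound 1 gives 33600 nM. Among the three compounds measured in this assay compound 1 holds the second highest number: compound 2, `CCO/N=C(/c1ccc(Br)cc1)C1CCN(C(C)CCNC(=O)c2c(Cl)cncc2Cl)CC1`, gives 33800 nM, a number that sits alongside that of compound 1 within the usual scatter, while compound 3, `COC(=O)c1cccc(OC(c2ccc(C(F)(F)F)cc2)C2CCN(C(C)CCNC(=O)c3c(Cl)cncc3Cl)CC2)c1`, gives 15200 nM.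

Compound 4, `CC(CCNC(=O)c1c(Cl)cncc1Cl)N1CCC(C(Oc2cccc(Cl)c2)c2ccc(C(F)(F)F)cc2)CC1`, has not yet been measured. It differs from compound 1 in one place: 3-chlorophenyl in place of 4-methylpyridin-2-yl on an oxygen on a saturated carbon. Among the measured compounds shown here, the only measured step that bears on this change is the one in which the same 4-methylpyridin-2-yl on the same oxygen was exchanged for another aromatic ring, namely a 2.2-fold lower number from compound 1 to compound 3 (0.34 log units; beyond the scatter), a modest shift downward. Replacing the ring with 3-chlorophenyl is therefore expected to give at most a small downward step in this assay, and possibly none beyond the scatter, as a 1.4-fold lower number from compound 1 to compound 4 (0.15 log units; within the scatter). The value of compound 4 is thus estimated at 24000 nM, with a likely range from 11000 nM to 48000 nM.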

Compound 4, half-maximal cytotoxic concentration: 8100 nM
Compound 4: middle estimate off by 3.0-fold (0.47 log units), on the high side; measured number below the stated range.
By their numbers in this assay, from the lowest: compounds 4 and 3 (each within the scatter of the next); then compounds 1 and 2 (each within the scatter of the next).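

With 3-chlorophenyl on this oxygen, this assay gives a 4.1-fold lower number from compound 1 to compound 4 (0.62 log units; beyond the scatter), so a lower number on leaving 4-methylpyridin-2-yl is no longer seen with the 3-(methoxycarbonyl)phenyl ring alone. In both cases, a ring of carbon only has replaced the ring with a hetero atom, and both changes point towards higher toxicity in this test. The two carbon-only rings cannot be told apart, since chloro in place of methoxycarbonyl on the aromatic carbon gives a 1.9-fold lower number from compound 3 to compound 4 (0.27 log units; within the scatter), and nothing available explains the drop from the pyridine ring.

As far as these compounds go, whether a plain phenyl ring without a substituent would group with compound 1 or with compound 3 and compound 4 remains open. So does the outcome for an unmethylated pyridine ring, or for a phenyl ring carrying an amine or a carboxylic acid.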